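A few compounds are considered here, and "the series" means these few. Any claim that something is new, unique, unknown or untested is made for them only; others in the source may bear on it.

Measured compounds:
Compound 1 `COc1cccc(C(=O)NCc2c(C)cc(C)[nH]c2=O)c1F`: in an assay on Sf9 cells for inhibition of histone-lysine N-methyltransferase EZH2 (Homo sapiens), read by scintillation counting, with a stated time of 60 min, in the presence of a further agent that is not named here (on this read-out lower numbers stand for stronger inhibition and higher numbers for weaker inhibition), compound 1 gives only the assay limit > 150000 nM.
Compound 2 `COc1cccc(C(=O)NCc2c(C)cc(C)[nH]c2=O)c1C`: in this assay compound 2 gives 5700 nM.

Compound 2 thus holds the only number shown; the other value is a limit (the limit of > 150000 nM in this assay, at which 1 of the 2 values shown sits). Compound 3 `COc1cccc(C(=O)NCc2c(C)cc(C)[nH]c2=O)c1O` differs from compound 2 by hydroxy in place of methyl on an aromatic carbon. Going by the values given here, the one measured step at this place is an at least 26-fold lower number from compound 1 to compound 2 (1.42 log units; beyond the scatter). Because the step of an at least 26-fold lower number from compound 1 to compound 2 (1.42 log units; beyond the scatter) was large, taking the methyl away again in compound 3 is expected to raise the number, though the size is uncertain. Compound 3 is estimated at 40000 nM, between 8000 nM and 150000 nM, an expected step of a 7.0-fold higher number from compound 2 to compound 3 (0.85 log units; beyond the scatter).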

Compound 3, half-maximal inhibitory concentration: 44000 nM
For compound 3 the middle estimate is 1.1-fold (0.04 log units) below the measured one; measured number inside the range.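

In this assay hydroxy in place of methyl gives a 7.7-fold higher number from compound 2 to compound 3 (0.89 log units; beyond the scatter) and hydroxy in place of fluoro gives an at least 3.4-fold lower number from compound 1 to compound 3 (0.53 log units; beyond the scatter) so that hydroxy falls between the other two groups. A lower number than that of compound 1 at this place is therefore not confined to methyl, although compound 2 keeps the lowest number of the three. The comparison with compound 1 gives only a minimum, since compound 1 stands at an assay limit: the limit of > 150000 nM in this assay, at which 1 of the 3 values shown sits. The compounds shown leave open how an amine, a chloro group or an ethyl chain would fare at this place. They also leave open whether the order of these groups would hold with the methoxy group replaced.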